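Taking the Side Ring Off the Shared Core

The source may report more compounds than this note shows. Statements on the series, on what has been measured and on what is new or still open speak of the compounds shown alone.

Compound 1 `Cc1n[nH]cc1-c1cccc2c1CCC2c1ncc[nH]1`: in a functional assay on CHO cells for agonist activity at Alpha-1A adrenergic receptor (Homo sapiens), read by FLIPR and calcium flux (on this read-out higher numbers stand for an effect only at larger amounts of compound and lower numbers for an effect already at smaller amounts), compound 1 gives 3 nM.
Compound 2 `c1ccc(-c2cccc3c2CCC3c2ncc[nH]2)nc1`: in this assay compound 2 gives 1150 nM.
Compound 3 `Cn1ccc(-c2cccc3c2CCC3c2ncc[nH]2)n1`: in this assay compound 3 reports only a limit, > 1300 nM, and no number.

As far as these compounds go, compound 3 therefore stands at the weak end of the three: it sits at the limit of > 1300 nM in this assay, at which 1 of the 3 values shown sits, so its true number is unknown beyond that. Compound 4 `c1ccc2c(c1)CCC2c1ncc[nH]1` strips the side ring away altogether; the change is hydrogen in place of 1-methyl-1H-pyrazol-3-yl on an aromatic carbon.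

Among the measured compounds shown here, no measured step removes the group outright, so the guide is indirect. The steps of a 380-fold higher number from compound 1 to compound 2 (2.58 log units; beyond the scatter) and an at least 430-fold higher number from compound 1 to compound 3 (2.63 log units; beyond the scatter) show that swapping one ring for another at this place can cost a great deal, while an at least 1.1-fold higher number from compound 2 to compound 3 (0.05 log units; that floor lies within the scatter) shows that the two weaker rings cannot be told apart. Whether losing the ring entirely costs more again, or changes little from the weak compound 3, is not settled by these data.

On that basis compound 4 is expected to remain weak in this assay, with an estimate of 2000 nM and a range from 300 nM to 15000 nM. The expected step is a step that the limit leaves unreadable from compound 3 to compound 4, with a fair chance that the measurement again reports only a limit.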

Compound 4, half-maximal effective concentration: 473 nM
Compound 4: middle estimate off by 4.2-fold (0.63 log units), on the high side; the range from low to high includes it.
By their numbers in this assay, from the lowest: compound 1; then compound 4; then compound 2. At a limit, above all of these: compound 3.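

Taking the side ring off entirely does not leave the compound worse off than the two weak rings do in this assay: the pyridin-2-yl ring gives way to hydrogen with a 2.4-fold lower number from compound 2 to compound 4 (0.39 log units; beyond the scatter), and the 1-methyl-1H-pyrazol-3-yl ring gives way to hydrogen with an at least 2.7-fold lower number from compound 3 to compound 4 (0.43 log units; beyond the scatter). So at this aromatic carbon these two rings are more than poor substitutes for the 3-methyl-1H-pyrazol-4-yl ring, since each gives a higher number than no ring at all, whereas the 3-methyl-1H-pyrazol-4-yl ring alone improves on hydrogen, as the reverse view of a 160-fold higher number from compound 1 to compound 4 (2.20 log units; beyond the scatter) shows. The step from compound 3 gives only a minimum size, because the value of compound 3 is a limit: the limit of > 1300 nM in this assay, at which 1 of the 4 values shown sits.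

The compounds shown do not tell which part of the 3-methyl-1H-pyrazol-4-yl ring accounts for its large advantage over hydrogen, since none separates the methyl from the ring that carries it. A pyrazol-4-yl ring without the methyl, or a small group such as an amine or a methoxy on the same carbon, would show how much of that advantage needs the whole ring.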